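From pyridazin-4-yl to pyrazin-2-yl on a sulfonyl sulfur

The compounds below may be only part of what the source reports. "The series", "measured", "known", "first", "only" and "open" are said of these compounds alone.

Measured in a physicochemical assay for lipophilicity, measured as octanol-water partition, at pH 7.4; on this read-out lower numbers stand for lower lipophilicity and higher numbers for higher lipophilicity:
- compound 1 `Cc1ccc2[nH]c(C(=O)N[C@H]3CN(S(=O)(=O)c4ccccc4)C[C@@H]3C(=O)NCCN(C)C)cc2c1`: 2.1
- compound 2 `Cc1ccc2[nH]c(C(=O)N[C@H]3CN(S(=O)(=O)c4cccnc4)C[C@@H]3C(=O)NCCN(C)C)cc2c1`: 1.4
- compound 3 `Cc1ccc2[nH]c(C(=O)N[C@H]3CN(S(=O)(=O)c4ccnnc4)C[C@@H]3C(=O)NCCN(C)C)cc2c1`: 0.7

Compound 3, at 0.7, is the lowest of the three, and compound 2 is its nearest neighbour. Compound 4 `Cc1ccc2[nH]c(C(=O)N[C@H]3CN(S(=O)(=O)c4cnccn4)C[C@@H]3C(=O)NCCN(C)C)cc2c1` differs from it only on the sulfonyl sulfur: pyrazin-2-yl in place of pyridazin-4-yl on a sulfonyl sulfur. Three measured steps fall at this place: a number 0.70 log units lower from compound 1 to compound 2 (beyond the scatter), a number 0.70 log units lower from compound 2 to compound 3 (beyond the scatter) and a number 1.40 log units lower from compound 1 to compound 3 (beyond the scatter). The first two are modest and the third is large. Each of them changed the atoms of the ring, whereas compound 3 and compound 4 have the same atoms, joined differently. Within the data shown here, no measured step shows such an exchange, so a much smaller step is expected in this assay, a slight rise that stays within the scatter. The expected step is a number 0.30 log units higher from compound 3 to compound 4 (within the scatter). The estimate for compound 4 is 1, with an expected range from 0.6 to 1.4.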

Compound 4, distribution coefficient: 1
Estimate against measurement, compound 4: no gap at the digits printed; the range from low to high includes it.
By their numbers in this assay, from the lowest: compounds 3 and 4 (each within the scatter of the next); then compound 2; then compound 1.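

In this assay, exchanging pyridazin-4-yl for pyrazin-2-yl on the sulfonyl sulfur, with the same atoms joined differently, gives a number 0.30 log units higher from compound 3 to compound 4 (within the scatter), so this exchange does not separate the two compounds. Compound 4 still stands apart from the pyridin-3-yl and phenyl compounds, with a number 0.40 log units lower from compound 2 to compound 4 (beyond the scatter) and a number 1.10 log units lower from compound 1 to compound 4 (beyond the scatter). Nothing measured here accounts for the size of these steps.

Going by these compounds, whether pyrimidin-5-yl, another ring with the same atoms, would fall with compound 3 and compound 4 remains open. So does the effect of an amine on the pyrazin-2-yl ring.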